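From a 3-bromophenyl amide to a fluorinated one

The source may hold more compounds than are shown below. What is called first, only, known or untested is meant among the compounds shown, and "the series" means these compounds.

In a functional assay on A549 cells (Homo sapiens) for cytotoxicity, read by MTT assay, with a stated time of 72 h (a lower number here means a stronger inhibitor, a higher number a weaker inhibitor), compound 1 (`O=C(CN1CCN(c2nnc(Cc3ccncc3)c3ccccc23)CC1)Nc1cccc(Br)c1`) gives 1530 nM. Among the measured compounds shown here, only one other compound in this small set has a number: compound 2 (`O=C(CN1CCN(c2nnc(Cc3ccccc3)c3ccccc23)CC1)Nc1ccc(F)c(C(F)(F)F)c1`) gives 2480 nM, and these two values lie within the usual scatter of each other, so they count as one level. Compound 3 (`Cc1ccc(F)cc1NC(=O)CN1CCN(c2nnc(Cc3ccccc3)c3ccccc23)CC1`) is reported in this assay as "not active" (no number reported), with no number attached.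

Compound 4 (`O=C(CN1CCN(c2nnc(Cc3ccncc3)c3ccccc23)CC1)Nc1ccc(F)c(C(F)(F)F)c1`) still awaits measurement. It keeps the core of compound 1 and changes one group: 4-fluoro-3-(trifluoromethyl)phenyl in place of 3-bromophenyl on an amide-type nitrogen. In words, 4-fluoro-3-(trifluoromethyl)phenyl stands in place of 3-bromophenyl on an amide-type nitrogen. For the measured compounds named here, no two measured compounds differ in only one place, so this swap has no direct precedent here. The nearest guide is compound 2, which carries the entering group and gives 2480 nM. On that basis, no step beyond the scatter is expected. The estimated step of a 1.3-fold higher number from compound 1 to compound 4 (0.12 log units; within the scatter) is small and points towards a slightly higher number. An outcome without a number remains possible, since compound 3 is reported as "not active" (no number reported). For compound 4 the expected value is 2000 nM, with an estimated range from 800 nM to 6000 nM.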

Compound 4, half-maximal inhibitory concentration: 16000 nM
For compound 4 the middle estimate is 8.0-fold (0.90 log units) below the measured one; the whole stated range lies below it.
By their numbers in this assay, from the lowest: compounds 1 and 2 (each within the scatter of the next); then compound 4.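

In this assay, placing 4-fluoro-3-(trifluoromethyl)phenyl instead of 3-bromophenyl on the amide-type nitrogen gives a 10-fold higher number from compound 1 to compound 4 (1.02 log units; beyond the scatter), the first direct sign in this set that the group at this place can change the cytotoxicity read-out. The other one-place comparison, pyridin-4-yl in place of phenyl on a saturated chain carbon bound to an aromatic carbon, gives a 6.5-fold higher number from compound 2 to compound 4 (0.81 log units; beyond the scatter), so with this fluorinated group on the amide the other end of the molecule matters too. Among the compounds shown here, compounds 1 and 2, each carrying only one of these two groups, sit at one level, and only compound 4, which combines them, stands apart at a weaker level, though nothing available here bears on the reason for this.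

The compounds shown leave open how 3-bromophenyl would behave with phenyl in place of pyridin-4-yl, which would show whether the pyridin-4-yl effect depends on the amide group. They also leave open whether the loss follows the trifluoromethyl group or the fluorine, and how a 3-chlorophenyl or 3-(trifluoromethyl)phenyl group would fare on the same nitrogen.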